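Swapping a hydroxyphenyl for a furan on the hydrazone arm

The compounds below may be only part of what the source reports. "The series", "measured", "known", "first", "only" and "open" are said of these compounds alone.

Of the compounds shown here, three of one shared core have been measured in a functional assay on A549 cells (Homo sapiens) for cytotoxicity, read by MTT assay, with a stated time of 48 h; on this read-out higher numbers stand for higher solubility and lower numbers for lower solubility. Compound 1 `O=C(N/N=C/c1ccco1)c1cc(-c2ccccc2)nn1Cc1ccccc1` gives 12500 nM, compound 2 `O=C(N/N=C/c1ccccc1O)c1cc(-c2ccccc2)nn1Cc1ccc(Cl)nc1` gives 45000 nM, and compound 3 `O=C(N/N=C/c1ccccc1O)c1cc(-c2ccc(Cl)cc2)nn1Cc1ccc(Cl)nc1` gives 22500 nM; the number for compound 3 sits within the scatter of both others. Among the compounds with values here, the one measured single step, a 2.0-fold lower number from compound 2 to compound 3 (0.30 log units; within the scatter), stays within the scatter. Compound 4 `O=C(N/N=C/c1ccco1)c1cc(-c2ccc(Cl)cc2)nn1Cc1ccc(Cl)nc1` differs from compound 3 by furan-2-yl in place of 2-hydroxyphenyl on a carbon with a double bond to nitrogen. Within the data shown here, no measured pair isolates this change; compound 1 and compound 2 carry these two groups but differ elsewhere too, so their values show nothing clean. The estimated step of a 1.5-fold lower number from compound 3 to compound 4 (0.18 log units; within the scatter) is therefore expected to be small, at most near the scatter. Compound 4 is expected to give about 15000 nM, within 7000 nM to 32000 nM.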

Compound 4, solubility: 70000 nM
For compound 4 the middle estimate is 4.7-fold (0.67 log units) below the measured one; the whole stated range lies below it.
By their numbers in this assay, from the lowest: compounds 1, 3, 2 and 4 (each within the scatter of the next, the first and the last beyond it).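

Within the data shown here, this pair gives the first clean reading of the change: on a carbon with a double bond to nitrogen, furan-2-yl in place of 2-hydroxyphenyl gives a 3.1-fold higher number from compound 3 to compound 4 (0.49 log units; beyond the scatter), a modest step beyond the scatter. The earlier compounds shown here could not show this, since compound 1 and compound 2 differ in more than this one place. Nothing measured here explains the step. As far as these compounds go, it rests on a single pair, so whether it holds with the other groups of compound 1 stays open. Also open, from the compounds shown here alone, is how an amine or a carboxylic acid would fare in this place.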